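This account rests on a few compounds, and the source may have more. Where it says the series, first, only, none or still open, it means among the compounds named here.

In a functional assay on A549 cells (Homo sapiens) for inhibition, read by XTT assay, with a stated time of 48 h (a lower number here means a stronger inhibitor, a higher number a weaker inhibitor), three compounds have been measured so far. Compound 1 `CC(=O)OC/C(=C/c1ccccc1F)C(=O)c1ccccc1` gives 20300 nM. Compound 2 `C=C(C(=O)c1ccc(OC)cc1)C(OC(C)=O)c1ccc(Cl)cc1Cl` gives 17600 nM, and compound 3 `C=C(C(=O)c1ccc(OC)cc1)C(OC(=O)c1ccccc1)c1ccc(Cl)cc1Cl` gives 79200 nM. Compound 3 thus stands highest of the three numbers, making it the weakest inhibitor measured, beyond the scatter from both of the others. The only single-place step among these compounds is a 4.5-fold higher number from compound 2 to compound 3 (0.65 log units; beyond the scatter), which puts a phenyl in place of a methyl on a carbonyl carbon.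

Compound 4 `C=C(C(=O)c1ccc(OC)cc1)C(OC(=O)c1ccccc1)c1ccc([N+](=O)[O-])cc1` differs from compound 3 in another place: 4-nitrophenyl in place of 2,4-dichlorophenyl on a saturated chain carbon bound to a double-bonded chain carbon and an oxygen next to a carbonyl group. Among the compounds with values here, no measured pair differs at this aromatic ring, so the step from compound 2 to compound 3 does not speak to it, and compound 1, built on a different skeleton, offers no comparison either. With nothing to point in either direction, the change is taken to leave the number where it is, with a wide range to admit the unknown. The expected step is therefore a 1.3-fold lower number from compound 3 to compound 4 (0.12 log units; within the scatter), not beyond the scatter. On that basis compound 4 is estimated at 60000 nM, most likely between 15000 nM and 200000 nM.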

Compound 4, half-maximal inhibitory concentration: 66600 nM
The estimate for compound 4 lay 1.1-fold (0.05 log units) below the measured number; measured number inside the range.
By their numbers in this assay, from the lowest: compounds 2 and 1 (each within the scatter of the next); then compounds 4 and 3 (each within the scatter of the next).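

In this assay, within the data shown here, the earlier compounds held no pair that differed at this aromatic ring, and the first such pair, with 4-nitrophenyl in place of 2,4-dichlorophenyl, gives a 1.2-fold lower number from compound 3 to compound 4 (0.08 log units; within the scatter). The two groups differ in their atoms, since the chlorine atoms leave while a nitrogen and 2 oxygen atoms enter, yet this assay does not separate compound 3 from compound 4, at least with phenyl on the carbonyl carbon. No measurement at hand explains this result.

From the compounds shown here alone, whether the same exchange would also leave the number within the scatter with methyl on the carbonyl carbon, as in compound 2, remains open. Also open, going by these compounds, is how this position would respond to a plain phenyl ring or to a ring bearing an amine or a carboxylic acid, since a single pair cannot show how widely the ring can vary.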